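The compounds below may be only part of what the source reports. "The series", "measured", "known", "first", "only" and "open" are said of these compounds alone.

Measured so far:
- compound 1 `Cc1ccc(OCC(=O)N(Cc2cccs2)c2cccnc2)cc1`: 198 nM
- compound 2 `CCCc1ccc(OCC(=O)N(CC)Cc2cccs2)cc1`: 1810 nM
- compound 3 `COc1ccc2oc(C(=O)N(Cc3cccs3)c3ccn[nH]3)cc2c1`: 1.1 nM

In an assay on HEK293 cells for agonist activity at transient receptor potential cation channel subfamily M member 8 (Homo sapiens), read by fluorescence and calcium flux, with a stated time of 15 min (a lower number here means that less compound is needed, a higher number that more compound is needed for the effect), compound 1 gives 198 nM and stands second highest of the three numbers. Its nearest neighbour is compound 2 at 1810 nM, a higher number and beyond the scatter; the furthest is compound 3 at 1.1 nM, far lower and well beyond the scatter. Among the measured compounds shown here, compounds 2 and 3 differ from compound 1 in more than one place, so no single step between them can be read off.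

The unmeasured compound 4 `Cc1ccc(OCC(=O)N(O)Cc2cccs2)cc1` follows from compound 1 by one change: hydroxy in place of pyridin-3-yl on an amide-type nitrogen. The pyridin-3-yl is the only aryl substituent on that nitrogen in compound 1, and compound 2, which also lacks a pyridin-3-yl on the amide nitrogen, gives a clearly higher number than compound 1. For the measured compounds named here, no measured pair shows this exact change, so the size of the step rests on that comparison alone.

The expectation is a step upward in this assay for compound 4, beyond the scatter. For compound 4 the estimated value is 3000 nM with a range of 600 nM to 15000 nM, which means an expected step of a 15-fold higher number from compound 1 to compound 4 (1.18 log units; beyond the scatter).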

Compound 4, half-maximal effective concentration: 8000 nM
Compound 4: middle estimate off by 2.7-fold (0.43 log units), on the low side; the range from low to high includes it.
By their numbers in this assay, from the lowest: compound 3; then compound 1; then compound 2; then compound 4.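

In this assay, the amide-type nitrogen whose other neighbours are a carbonyl carbon and a saturated chain carbon now has its first direct reading: hydroxy in place of pyridin-3-yl gives a 40-fold higher number from compound 1 to compound 4 (1.61 log units; beyond the scatter), a large step beyond the scatter. The pyridin-3-yl, a six-membered aromatic ring of 6 heavy atoms, therefore cannot be exchanged for this group of 1 heavy atom without a clear rise in the amount of compound needed, and the change also brings in 1 hydrogen-bond donor, so ring loss, size and donor gain are all bundled into this one step. Nothing measured here indicates which of these accounts for the rise.

From the compounds shown here alone, it remains open whether a phenyl, a pyridin-4-yl or a simple methyl on the same nitrogen would keep the number of compound 1 or move it as far as hydroxy does, which would begin to separate the ring from the donor. Among the compounds shown here, compound 2 and compound 3 differ from the other compounds in more than one place, so no steps involving them can be read.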